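The compounds below may be only part of what the source reports. "The series", "measured", "known", "first", "only" and "open" are said of these compounds alone.

For the measured compounds named here, compound 1 `CCC1(Cc2ccccc2)OS(=O)(=O)C=C1OCC#N` is one of three compounds measured in an ADME assay on HEL cells (Homo sapiens) for cytotoxicity, with a stated time of 3 days (on this read-out higher numbers stand for lower toxicity in this test and lower numbers for higher toxicity in this test), and each of them gives only a limit. In this assay compound 1 gives > 400000 nM, a limit of the assay and not a number. Compound 2 `CCC1(Cc2ccccc2)OS(=O)(=O)C=C1OC` gives > 400000 nM, again a limit. Compound 3 `CC(C)CC1(Cc2ccccc2)OS(=O)(=O)C=C1OCc1ccccc1` gives >= 80000 nM, also a limit. Going by the values given here, the single measured step that bears on the change, a step that the two limits leave unreadable from compound 1 to compound 2, cannot be sized because both of its ends sit at the limit of > 400000 nM in this assay, at which 2 of the 3 values shown sit. Compound 4 `CCC1(Cc2ccccc2)OS(=O)(=O)C=C1OCc1ccc(Cl)c(Cl)c1` differs from compound 1 by 3,4-dichlorophenyl in place of cyano on a saturated chain carbon bound to an oxygen on an unsaturated carbon. With compound 3 resting at the limit of >= 80000 nM in this assay, at which 1 of the 3 values shown sits, and no readable step available, no shift beyond the scatter is expected in this assay. Compound 4 is therefore expected to give 200000 nM (from 50000 nM to 400000 nM), a step of an at least 2.0-fold lower number from compound 1 to compound 4 (0.30 log units; that floor lies within the scatter), most probably reported once more as a limit.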

Compound 4, minimum cytotoxic concentration: >= 20000 nM
Compound 4 gave a limit, no number; the forecaster's own chance of this, stated with the estimate: 60%; the middle value does not contradict the limit.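

Compound 1, compound 2 and compound 4 all give limits, not numbers, and the steps from compound 1 and from compound 2 to compound 4 cannot be read. The compounds shown leave open whether 3,4-dichlorophenyl, cyano or hydrogen at this place makes any difference in this assay.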